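Moving the chlorines on a dichlorophenyl ether tail

A few compounds are considered here, and "the series" means these few. Any claim that something is new, unique, unknown or untested is made for them only; others in the source may bear on it.

Measured so far:
- compound 1 `CN1CCN(c2nc(N)nc(CCCOc3ccc(Cl)c(Cl)c3)n2)CC1`: 4880 nM
- compound 2 `CC(Oc1cccc(Cl)c1Cl)c1nc(N)nc(N2CCN(C)CC2)n1`: 12600 nM

Of the compounds shown here, two sharing a core have been tested in an assay on HEK293 cells for displacement of a labelled ligand from 5-hydroxytryptamine receptor 7 (Homo sapiens), read by scintillation counting, with a stated time of 1 h; a lower number here means a stronger inhibitor, a higher number a weaker inhibitor. In this assay compound 1 gives 4880 nM, the lower of the two numbers, and compound 2 gives 12600 nM, a higher number that lies beyond the usual scatter. Compound 2 differs from compound 1 in more than one place, so its weaker result cannot be tied to any single change.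

Compound 3 `CN1CCN(c2nc(N)nc(CCCOc3cccc(Cl)c3Cl)n2)CC1` is not yet measured. It differs from compound 1 by 2,3-dichlorophenyl in place of 3,4-dichlorophenyl on an oxygen on a saturated carbon. Within the data shown here, no measured pair isolates this change, so the expected step rests on little. A modest move towards a higher number in this assay, perhaps not clearly beyond the scatter, is expected. The step from compound 1 to compound 3 is estimated at a 1.5-fold higher number from compound 1 to compound 3 (0.19 log units; within the scatter). Compound 3 is therefore expected to give about 7500 nM, within a range from 2500 nM to 22000 nM.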

Compound 3, inhibition constant: 8590 nM
Compound 3: middle estimate off by 1.1-fold (0.06 log units), on the low side; measured number inside the range.
By their numbers in this assay, from the lowest: compounds 1, 3 and 2 (each within the scatter of the next, the first and the last beyond it).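

Compounds 1 and 3 have the same atoms and differ only in where the two chlorines sit on the phenyl ring, so this pair isolates a change that the comparison with compound 2 could not. In this assay, 2,3-dichlorophenyl in place of 3,4-dichlorophenyl on an oxygen on a saturated carbon gives a small step (a 1.8-fold higher number from compound 1 to compound 3 (0.25 log units; within the scatter)), so these two chlorine arrangements cannot be told apart in this assay. Nothing else available here bears on this result.

On these data alone, it remains open whether a larger difference would appear with another ring on the same oxygen, such as 3,5-dichlorophenyl, a phenyl with a single chlorine or a phenyl with no chlorine. A longer chain between the core and the oxygen is also untested among these compounds.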